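This account rests on a few compounds, and the source may have more. Where it says the series, first, only, none or still open, it means among the compounds named here.

Measured compounds:
Compound 1 `CCCC(=O)Nc1ccc(S(=O)(=O)Oc2ccccc2I)cc1`: 2000 nM
Compound 2 `O=C(CCl)Nc1ccc(S(=O)(=O)Oc2ccccc2I)cc1`: 600 nM

Of the compounds shown here, two have so far been measured in a functional assay on HT-1080 cells (Homo sapiens) for antiproliferative activity, read by sulforhodamine B assay, with a stated time of 48 h; on this read-out higher numbers stand for weaker inhibition and lower numbers for stronger inhibition. Compound 1 `CCCC(=O)Nc1ccc(S(=O)(=O)Oc2ccccc2I)cc1` gives 2000 nM in this assay, and compound 2 `O=C(CCl)Nc1ccc(S(=O)(=O)Oc2ccccc2I)cc1` gives 600 nM. Among the compounds with values here, compound 2 therefore has the lowest number of the two, and the one step measured, a 3.3-fold lower number from compound 1 to compound 2 (0.52 log units; beyond the scatter), lies beyond the scatter.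

The next compound, compound 3 `O=C(Nc1ccc(S(=O)(=O)Oc2ccccc2I)cc1)NC1CC1`, differs from compound 2 at the carbonyl carbon: cyclopropylamino in place of chloromethyl on a carbonyl carbon. Within the data shown here, only one measured step bears on this change, a 3.3-fold lower number from compound 1 to compound 2 (0.52 log units; beyond the scatter), and it concerns the chlorine that compound 3 gives up; the cyclopropylamino that enters has no counterpart among the measured compounds. Because a 3.3-fold lower number from compound 1 to compound 2 (0.52 log units; beyond the scatter) accompanied the entry of chloro, its departure in compound 3 is expected to move the number back toward that of compound 1, with the entering group adding an unmeasured contribution. The step of a 2.5-fold higher number from compound 2 to compound 3 (0.40 log units; beyond the scatter) is accordingly expected to be a rise, of modest size. Compound 3 is estimated at 1500 nM, with a range from 400 nM to 6000 nM.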

Compound 3, half-maximal inhibitory concentration: 1300 nM
The estimate for compound 3 lay 1.2-fold (0.06 log units) above the measured number; the range from low to high includes it.
By their numbers in this assay, from the lowest: compound 2; then compounds 3 and 1 (each within the scatter of the next).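

In this assay the carbonyl carbon accepts cyclopropylamino, which brings a three-membered ring and a hydrogen-bond donor, but the change from chloromethyl gives a 2.2-fold higher number from compound 2 to compound 3 (0.34 log units; beyond the scatter) and so does not keep the number of compound 2. Set against propyl on the same carbon, the new group gives a 1.5-fold lower number from compound 1 to compound 3 (0.19 log units; within the scatter) and so compound 3 and compound 1 cannot be told apart, which leaves chloromethyl as the only one of the three groups whose compound stands beyond the scatter from both others. The data offer no measurement that would account for these differences.

From the compounds shown here alone, whether the lower number of compound 2 goes with the chlorine or with the short chain stays open, and an acetyl or a bromomethyl group on the same carbon would help to separate the two. Going by these compounds, it is equally open whether the ring in cyclopropylamino matters at all, a question that an open-chain ethylamino or a larger cyclopentylamino group on this carbonyl carbon would address.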